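Compound 2 to compound 4: a solubility estimate

The source may report more compounds than this note shows. Statements on the series, on what has been measured and on what is new or still open speak of the compounds shown alone.

Values measured in a physicochemical assay for solubility, in phosphate buffer, measured as kinetic solubility, at pH 7.4 (on this read-out higher numbers stand for higher solubility and lower numbers for lower solubility), are as follows.
Compound 1 (`Cc1ccccc1-c1nc(CN2CCC(C(=O)NCCCN3CCCC(CC(C)C)C3)CC2)c(C)o1`): 54.9 ug/mL
Compound 2 (`Cc1oc(-c2c(Cl)cccc2Br)nc1CN1CCC(C(=O)NCCCN2C[C@H](C)C[C@H](C)C2)CC1`): > 83 ug/mL
Compound 3 (`Cc1ccccc1-c1nc(CN2CCC(C(=O)N3CCN(C4CCN(C)CC4)CC3)CC2)c(C)o1`): > 71 ug/mL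

Only compound 1 has an exact number here. For compound 2, this assay reports the limit > 83 ug/mL and no exact number. For compound 3, this assay likewise reports only a limit, > 71 ug/mL and no exact number.

Compound 4 (`COc1cccc(F)c1-c1nc(CN2CCC(C(=O)NCCCN3C[C@H](C)C[C@H](C)C3)CC2)c(C)o1`) has not yet been measured. It differs from compound 2 in one place, on an aromatic carbon of a five-membered aromatic ring with 1 nitrogen and 1 oxygen: 2-fluoro-6-methoxyphenyl in place of 2-bromo-6-chlorophenyl (2-fluoro-6-methoxyphenyl in place of 2-bromo-6-chlorophenyl on an aromatic carbon).

Among the compounds with values here, no pair of measured compounds shows this swap, so there is no direct precedent for its size. Within the data shown here, the expectation therefore starts from compound 2, whose limit > 83 ug/mL is the only reading for the compound that carries the departing group. The estimated change (an at least 1.1-fold lower number from compound 2 to compound 4 (0.06 log units; that floor lies within the scatter)) is expected to stay within the usual scatter, with no clear direction. The lower end of the range leaves room for a result like that of compound 1, which gives 54.9 ug/mL in this assay as an exact number. Compound 4 may also return only a limit. For compound 4, the estimated value is 72 ug/mL (expected range 45 ug/mL to 85 ug/mL).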

Compound 4, solubility: > 74 ug/mL
Compound 4: no number, only a limit; the forecaster's own chance of this, stated with the estimate: 70%; at least 1.0-fold (0.01 log units) between middle value and limit.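

Compound 2 and compound 4 each return only a limit in this assay, and two limits give no readable step between them. The compounds shown leave open whether 2-fluoro-6-methoxyphenyl in place of 2-bromo-6-chlorophenyl makes any difference to the solubility of compound 4 compared with compound 2, and in which direction.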